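This account rests on a few compounds, and the source may have more. Where it says the series, first, only, none or still open, it means among the compounds named here.

Measured in a functional assay on the whole organism (Tail, strain ICR) with Mus musculus as the target, in the tail flick test, with a stated time of 30 min, at a dose of 25 umol/kg by the oral route; a lower number here means a weaker effect, a higher number a stronger effect of the compound at the dose given:
compound 1 `NC(=O)CC[C@H](NC(=O)CN(c1ncnc2c1ncn2C1CCCCO1)C1CC1)C(=O)OCc1ccccc1` gives 47%
compound 2 `CSCC[C@H](NC(=O)CN(c1nc(Cl)nc2[nH]cnc12)C1CC1)C(=O)OCc1ccccc1` gives 22.2%
compound 3 `O=C(O)C[C@H](NC(=O)CN(c1nc(Cl)nc2[nH]cnc12)C1CC1)C(=O)O` gives 19.9%

Compound 1 holds the highest of the three numbers in this assay; compound 2 stands a step below it that is beyond the usual scatter, and compound 3 stands a little further below, also beyond the scatter. Within the data shown here, none of the measured compounds differ from one another in a single place, so no computed step is available. Compound 4 `CC(C)C[C@H](NC(=O)CN(c1ncnc2c1ncn2C1CCCCO1)C1CC1)C(=O)OCc1ccccc1` differs from compound 1 by isopropyl in place of carbamoylmethyl on a saturated chain carbon, two bonds along the chain from an amide-type nitrogen and a carbonyl carbon. Among the measured compounds shown here, no measured pair shows this change, so its size is uncertain; a modest step downward, possibly no larger than the scatter, is expected as a number 9 percentage points lower from compound 1 to compound 4 (within the scatter). Compound 4 is therefore estimated at 38%, with a range from 15% to 60%.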

Compound 4, a percentage reported as activity, at one dose (the size of the read-out at that dose, not a potency): 26.2%
Estimate against measurement, compound 4: 11.8 percentage points above; the range from low to high includes it.
By their numbers in this assay, from the lowest: compounds 3, 2 and 4 (each within the scatter of the next); then compound 1.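

In this assay, among these compounds, the replacement of carbamoylmethyl by isopropyl, on a saturated chain carbon, two bonds along the chain from an amide-type nitrogen and a carbonyl carbon, gives a number 20.8 percentage points lower from compound 1 to compound 4 (beyond the scatter) and provides the first comparison that differs in one place. The group at this position therefore matters to the read-out, with carbamoylmethyl the better of the two. No measurement available explains the step.

As far as these compounds go, how an amine, a carboxylic acid or a longer chain at this position would compare with carbamoylmethyl stays open. From the compounds shown here alone, whether the step carries over to the core of compound 2 also stays open.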